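Moving the Chlorine on a Weakly Cytotoxic Compound

The source may hold more compounds than are shown below. What is called first, only, known or untested is meant among the compounds shown, and "the series" means these compounds.

In a functional assay on A549 cells (Homo sapiens) for cytotoxicity, read by MTT assay, with a stated time of 72 h (on this read-out lower numbers stand for stronger inhibition and higher numbers for weaker inhibition), the measured compounds are:
- Compound 1 `COc1ccc(/C=C2\CCC/C(=C\c3ccccc3Cl)C2=O)cc1OC` gives > 20000 nM as a limit of the assay, not a number
- Compound 2 `COc1ccc(/C=C2\CCC/C(=C\c3cccc(Cl)c3)C2=O)cc1OC` gives 11000 nM as a measured number

For the measured compounds named here, compound 2 holds the only true number so far, so it has no measured neighbour against which to rank it firmly. Compound 3 `COc1ccc(/C=C2\CCC/C(=C\c3ccc(Cl)cc3)C2=O)cc1OC` has not yet been measured. It carries 4-chlorophenyl in place of 3-chlorophenyl on a double-bonded chain carbon bound to a double-bonded ring carbon, and nothing else changes.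

Going by the values given here, one measured step bears on this swap, the one that brought in the 3-chlorophenyl group. That step is an at least 1.8-fold lower number from compound 1 to compound 2 (0.25 log units; that floor lies within the scatter) and so does not clearly exceed the usual scatter. Going by these compounds, its true size stays open because the limit of > 20000 nM in this assay, at which 1 of the 2 values shown sits, applies to it. This gives no firm basis for a direction, so the estimate stays close to compound 2 at 11000 nM in this assay and allows for a weak result. The expected change is a 1.1-fold lower number from compound 2 to compound 3 (0.04 log units; within the scatter) and is not expected to exceed the scatter. Compound 3 is estimated at 10000 nM with an expected range from 4500 nM to 20000 nM in this read-out.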

Compound 3, half-maximal inhibitory concentration: 10100 nM
Estimate against measurement, compound 3: 1.0-fold (0.00 log units) below; the range from low to high includes it.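

In this assay the swap of the 3-chlorophenyl group for the 4-chlorophenyl group gives a 1.1-fold lower number from compound 2 to compound 3 (0.04 log units; within the scatter) and so does not separate the two compounds. For the compounds shown here, this is the first comparison at this place on the chain with a true number at both ends, and it shows that, for these two groups, the same atoms joined differently leave cytotoxicity in the same weak range. The other new step, an at least 1.9-fold lower number from compound 1 to compound 3 (0.29 log units; that floor lies within the scatter), cannot show whether the 2-chlorophenyl group truly differs from the 4-chlorophenyl group, because its true size is held open by a limit and not a number: the limit of > 20000 nM in this assay, at which 1 of the 3 values shown sits.

Chlorine is the only group on this ring in the compounds shown, so it remains open whether an amine or a carboxylic acid at this place would bring the number clearly below those of compound 2 and compound 3. Going by these compounds, it also remains open whether any change to the shared core, rather than to this ring, would have a larger effect on these cells.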